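The source may report more compounds than this note shows. Statements on the series, on what has been measured and on what is new or still open speak of the compounds shown alone.

Measured compounds:
compound 1 `Cc1ccc(C(=O)N[C@@H](C(=O)N2CCC(c3ccc(Cl)cc3)CC2)C(C)C)cc1`, 25 nM
compound 2 `O=C(N[C@@H](C(=O)N1CCC(c2ccc(Cl)cc2)CC1)C1CCCCC1)c1ccccc1`, 121 nM
compound 3 `CC[C@@H](C)[C@@H](NC(=O)c1ccccc1)C(=O)N1CCC(c2ccc(Cl)cc2)CC1`, 45 nM

In an assay on THP-1 cells for displacement of a labelled ligand from C-C chemokine receptor type 1 (Homo sapiens) (on this read-out lower numbers stand for stronger inhibition and higher numbers for weaker inhibition), compound 1 sits at the low end of the three numbers; its gap to compound 2 is beyond the scatter, while its gap to compound 3 is within it. Compound 4 `CC(C)[C@@H](NC(=O)c1ccc(F)cc1)C(=O)N1CCC(c2ccc(Cl)cc2)CC1` differs from compound 1 by one change: fluoro in place of methyl on an aromatic carbon. Among the compounds with values here, the only measured step, a 2.7-fold lower number from compound 2 to compound 3 (0.43 log units; beyond the scatter), concerns the saturated chain carbon and says nothing about the aromatic ring where the new group sits, so no measured step bears directly on this change. With no guide from the data, the number for compound 4 is expected to stay close to that of compound 1, giving an estimated step of a 1.2-fold higher number from compound 1 to compound 4 (0.08 log units; within the scatter). Compound 4 is therefore estimated at 30 nM, between 12 nM and 80 nM.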

Compound 4, half-maximal inhibitory concentration: 118 nM
Compound 4: middle estimate off by 3.9-fold (0.59 log units), on the low side; measured number above the stated range.
By their numbers in this assay, from the lowest: compounds 1 and 3 (each within the scatter of the next); then compounds 4 and 2 (each within the scatter of the next).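

In this assay, within the data shown here, the exchange gives a 4.7-fold higher number from compound 1 to compound 4 (0.67 log units; beyond the scatter) and is the first measured step at this aromatic carbon. It shows that the number responds to which group sits here, even though methyl and fluoro each count one heavy atom and neither adds a ring, donor, acceptor or charge. No measured evidence on the origin of this step is available. The compounds shown leave open how ethyl, methoxy or nitrile at this carbon would compare with methyl and fluoro, and whether the same exchange would give a similar step with sec-butyl or cyclohexyl on the saturated chain carbon.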